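Turning One Stereocentre: From Compound 1 to Compound 4

This account rests on a few compounds, and the source may have more. Where it says the series, first, only, none or still open, it means among the compounds named here.

Compound 1, `CC(C)(N)C(=O)N[C@H](COCc1ccccc1)c1nnnn1[C@H](CC#N)COc1ccccc1`: 0.4 nM
Compound 2, `CC(C)(N)C(=O)N[C@H](COCc1ccccc1)c1nnnn1C(/C=C/c1ccccc1)CC#N`: 62 nM; 0.5 nM (2 entries)
Compound 3, `CC(C)(N)C(=O)N[C@H](COCc1ccccc1)c1nnnn1C(CC#N)COc1ccccc1F`: 64 nM; 0.6 nM (2 entries)

The three measured compounds share one core and one amide arm and differ only in the group carried on the core nitrogen. In a functional assay on H4 cells for agonist activity at growth hormone secretagogue receptor type 1 (Homo sapiens), read by FLIPR (on this read-out higher numbers stand for an effect only at larger amounts of compound and lower numbers for an effect already at smaller amounts), compound 1 gives 0.4 nM, the only single number shown; its two further entries carry no single number. Compound 2 and compound 3, both drawn without a set configuration at the chain carbon, each return more than one entry that fall wide apart, as the several entries of compound 2 in this assay, 62 nM; 0.5 nM (2 entries) and the several entries of compound 3 in this assay, 64 nM; 0.6 nM (2 entries) show. Among the measured compounds shown here, no step between measured compounds can be drawn from this set, so each of those spreads is reported only as it stands.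

Compound 4, `CC(C)(N)C(=O)N[C@H](COCc1ccccc1)c1nnnn1[C@@H](CC#N)COc1ccccc1`, is the next compound. It differs from compound 1 in that (the two compounds have the same atoms and bonds and differ only in configuration as drawn: 1 of 2 stereo elements differ; a stereocentre at a saturated chain carbon is drawn R in compound 1 and S in compound 4). Because the entries of compound 2 in the several entries of compound 2 in this assay, 62 nM; 0.5 nM (2 entries) and of compound 3 in the several entries of compound 3 in this assay, 64 nM; 0.6 nM (2 entries) lie so far apart where the chain carbon is left undefined, compound 4 is expected to sit well beyond the scatter on the weaker side, with an expected step of a 75-fold higher number from compound 1 to compound 4 (1.88 log units; beyond the scatter). Compound 4 is therefore estimated at 30 nM in this assay, in a range from 1 nM to 300 nM.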

Compound 4, half-maximal effective concentration: 19 nM
Beside the measured number, compound 4's estimate is 1.6-fold (0.20 log units) above it; low and high end bracket the measured number.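

In this assay the change from R to S at the saturated chain carbon gives a 48-fold higher number from compound 1 to compound 4 (1.68 log units; beyond the scatter), and this whole step can be placed on that one stereocentre because nothing else separates the pair: the fact that compounds 1 and 4 differ only in the configuration as drawn. The position is therefore sensitive to configuration on this read-out, and the R form, compound 1, is the one that acts at smaller amounts, while the S form, compound 4, still has an effect in the low nanomolar range rather than losing it altogether. The earlier compounds shown here showed a wide gap only as entries at an undefined chain carbon, with neither number tied to a configuration, and this pair now gives such a gap a direction for one defined side chain, though only for that side chain: the several entries of compound 3 in this assay, 64 nM; 0.6 nM (2 entries).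

Which entry of compound 2 or compound 3 belongs to which configuration stays open, so it cannot be said whether R over S also holds for those side chains. Also open, going by these compounds, is how far the same preference would survive with a carboxylic acid or a primary amide in place of the nitrile on this carbon.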